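The source may report more compounds than this note shows. Statements on the series, on what has been measured and on what is new or still open speak of the compounds shown alone.

Measured compounds:
- compound 1, `O=C(O)CC/C=C\CO[C@H]1[C@@H](OCc2ccc(-c3ccccc3)cc2)CC[C@@H]1N1CCCCC1`: 10 nM; 7.94 nM (2 entries)
- compound 2, `CC(=O)NCc1ccccc1-c1ccc(COC2CC[C@H](N3CCCCCC3)[C@H]2OC/C=C\CCC(=O)O)cc1`: 25.1 nM
- compound 3, `O=C(O)CC/C=C\CO[C@H]1[C@@H](OCc2ccc(-c3ccccc3CO)cc2)CC[C@@H]1N1CCCCCC1`: 1.59 nM

These three share one core and are compared in a functional assay on blood for antagonist activity at thromboxane A2 receptor (Homo sapiens); on this read-out lower numbers stand for tighter binding and higher numbers for weaker binding. Among the two compounds with a single number, compound 2 stands at the weaker end: its nearest neighbour, compound 3, gives a clearly lower number, a gap well beyond the scatter of repeats. Compound 1 has two entries close to each other, (the several entries of compound 1 in this assay, 10 nM; 7.94 nM (2 entries)), which shows how tightly repeats of this measurement usually agree.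

The step under study leads from compound 2 to compound 4, `O=C(O)CC/C=C\CO[C@H]1C(OCc2ccc(-c3ccc(CO)cc3)cc2)CC[C@@H]1N1CCCCCC1`. The structural change is 4-(hydroxymethyl)phenyl in place of 2-(acetamidomethyl)phenyl on an aromatic carbon; in words, 4-(hydroxymethyl)phenyl in place of 2-(acetamidomethyl)phenyl on an aromatic carbon, para to a large group. Compound 4 keeps the seven-membered amine ring of compound 2 and compound 3, and it carries a hydroxymethyl group on the outer ring, as compound 3 does.

Since compound 3, also carrying a hydroxymethyl group, gives 1.59 nM, a move toward tighter binding is expected for compound 4, larger than the scatter. The estimated step is a 5.0-fold lower number from compound 2 to compound 4 (0.70 log units; beyond the scatter). Compound 4 is expected to give about 5 nM in this assay, within a range from 1.5 nM to 16 nM.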

Compound 4, dissociation constant: 3.16 nM
Estimate against measurement, compound 4: 1.6-fold (0.20 log units) above; the measured number falls inside the stated range.
By their numbers in this assay, from the lowest: compounds 3 and 4 (each within the scatter of the next); then compound 2.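

In this assay, this outer aromatic ring proves sensitive to what it carries: putting 4-(hydroxymethyl)phenyl in place of 2-(acetamidomethyl)phenyl gives a 7.9-fold lower number from compound 2 to compound 4 (0.90 log units; beyond the scatter). Among the compounds shown here, this is the first measured step at this position, and it is a real change rather than noise, since repeat measurements of one compound agree far more closely than this: the several entries of compound 1 in this assay, 10 nM; 7.94 nM (2 entries). The result also adds a second compound with a hydroxymethyl group to the tight end of the series, as compound 3 gives 1.59 nM and compound 4 gives 3.16 nM, two values within the scatter of each other, so neither can be ranked above the other.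

The step changes both the group and where it sits on the ring, so the compounds shown cannot tell whether losing the acetamidomethyl group or the new placement accounts for the tighter binding, a question that 4-(acetamidomethyl)phenyl would help to separate. As far as these compounds go, it also remains open how this position would respond to a different group in the same place, such as an aminomethyl group, which carries an amine, or a carboxylic acid.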